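The compounds below may be only part of what the source reports. "The series", "measured", "known", "first", "only" and "open" are said of these compounds alone.

Among the measured compounds shown here, in a functional assay on HepG2 cells (Homo sapiens) for inhibition, read by sulforhodamine B assay, with a stated time of 72 h (a higher number here means a weaker inhibitor, a lower number a stronger inhibitor), compound 3, `C[C@H](Nc1ncnc2[nH]cnc12)c1nn(-c2cccnc2)c2cc(F)ccc12`, gives 37500 nM, the only actual number in this small set. Compound 1, `C[C@H](Nc1ncnc2[nH]cnc12)c1nn(-c2cccnc2)c2cc(Cl)ccc12`, reaches only a limit, > 40000 nM. Compound 2, `C[C@H](Nc1nc(N)nc2[nH]cnc12)c1nn(-c2cccnc2)c2cc(F)ccc12`, also reaches only a limit, > 40000 nM. Two measured steps lead to compound 3. Fluoro in place of chloro gives an at least 1.0-fold lower number from compound 1 to compound 3 (0.02 log units; that floor lies within the scatter), and hydrogen in place of amino gives an at least 1.0-fold lower number from compound 2 to compound 3 (0.02 log units; that floor lies within the scatter). Both sizes are only floors because of the limit of > 40000 nM in this assay, at which 2 of the 3 values shown sit.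

Compound 4, `C[C@H](Nc1ncnc2[nH]cnc12)c1nn(-c2cccc(S(C)(=O)=O)c2)c2cc(F)ccc12`, differs from compound 3 elsewhere, with 3-(methylsulfonyl)phenyl in place of pyridin-3-yl on an aromatic nitrogen. Neither measured step touches that place, since compounds 1, 2 and 3 all carry pyridin-3-yl there, so they offer no measured size for this change. For the measured compounds named here, they show only that two other changes left no step beyond the scatter. The expectation therefore rests on compound 3 at 37500 nM, and no step beyond the scatter is expected in this assay, in either direction. The expected change is a 1.1-fold lower number from compound 3 to compound 4 (0.03 log units; within the scatter). A report of the limit alone would be no surprise. For compound 4 the estimated value is 35000 nM, with an expected range from 15000 nM to 70000 nM.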

Compound 4, half-maximal inhibitory concentration: 14800 nM
Compound 4: the middle estimate sits 2.4-fold (0.37 log units) above what was measured, and the stated range ends above it.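

In this assay, the place on an aromatic nitrogen of the five-membered aromatic ring proves to be one where a change of group moves the number, with 3-(methylsulfonyl)phenyl in place of pyridin-3-yl giving a 2.5-fold lower number from compound 3 to compound 4 (0.40 log units; beyond the scatter). Among the compounds shown here, this is the only step in the set that is printed as beyond the scatter, whereas the steps leading from compound 1 and compound 2 to compound 3 reached only floors within it. The change exchanges a six-membered aromatic ring with 1 hetero atom for one of carbon only and brings in 2 double bonds outside aromatic rings, and this single step does not separate those parts from each other.

As far as these compounds go, whether a plain phenyl, or a phenyl carrying an amine or a carboxylic acid, would move the number further at this place stays open, as does whether the step would hold with chloro in place of fluoro or with the added amino group of compound 2. The sizes of those two earlier changes also stay open, since they can be read only as floors: the limit of > 40000 nM in this assay, at which 2 of the 4 values shown sit.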